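Aryl phosphate nucleoside series: stability notes

This account rests on a few compounds, and the source may have more. Where it says the series, first, only, none or still open, it means among the compounds named here.

Measured compounds:
- compound 1, `Cc1cn([C@H]2C[C@H](N=[N+]=[N-])[C@@H](COP(=O)(O)Oc3cccnc3Cl)O2)c(=O)[nH]c1=O`: 16.3 h
- compound 2, `O=c1ccn([C@H]2CC[C@@H](COP(=O)(O)Oc3ccncc3)O2)c(=O)[nH]1`: 23.6 h
- compound 3, `Cc1cn([C@H]2C[C@H](N=[N+]=[N-])[C@@H](COP(=O)(O)Oc3ccccc3)O2)c(=O)[nH]c1=O`: 9.47 h

In a physicochemical assay for metabolic stability, read by HPLC (on this read-out lower numbers stand for a shorter-lived compound and higher numbers for a longer-lived compound), compound 2 gives 23.6 h, the highest of the three numbers. Compound 1 sits nearest to it, within the scatter, while compound 3 sits furthest from it, beyond the scatter. For the measured compounds named here, the one single-point step measured so far, a 1.7-fold lower number from compound 1 to compound 3 (0.24 log units; within the scatter), exchanges an aryl ring on the phosphate oxygen for phenyl and stays within the scatter.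

Compound 4, `O=c1ccn([C@H]2CC[C@@H](COP(=O)(O)Oc3ccccc3)O2)c(=O)[nH]1`, has not yet been measured in this assay. It differs from compound 2 in one place: phenyl in place of pyridin-4-yl on an oxygen. The step from compound 1 to compound 3 is the closest comparison, as it too puts phenyl in place of a nitrogen-containing ring on the phosphate oxygen, though the ring it removes is not the same one and the core differs. On that basis a small drop is expected, a 1.7-fold lower number from compound 2 to compound 4 (0.23 log units; within the scatter), of a size that would not clearly stand out from the scatter. Compound 4 is therefore expected to give about 14 h, with a plausible range from 7 h to 28 h.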

Compound 4, half-life: 25.1 h
Beside the measured number, compound 4's estimate is 1.8-fold (0.25 log units) below it, and the stated range covers the measured number.
By their numbers in this assay, from the lowest: compounds 3, 1, 2 and 4 (each within the scatter of the next, the first and the last beyond it).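

In this assay the exchange of pyridin-4-yl for phenyl on the oxygen whose other neighbour is phosphorus gives a 1.1-fold higher number from compound 2 to compound 4 (0.03 log units; within the scatter) and so leaves no difference that this read-out can resolve on the core of compound 2. The earlier step of a 1.7-fold lower number from compound 1 to compound 3 (0.24 log units; within the scatter) also stayed within the scatter, but it removed 2-chloropyridin-3-yl on another core and could not speak for the unsubstituted ring; compound 4 now shows that, on this core, the ring nitrogen of pyridin-4-yl is not needed for a half-life matching that of compound 2, since phenyl serves equally well at this position. No supporting data bear on why the two numbers match.

The compounds shown hold no pair that differs only in the core, so what the core itself contributes to the half-life stays open. As far as these compounds go, it also stays open whether any change at this oxygen moves the number beyond the scatter, for example a phenyl ring carrying an amine or a carboxylic acid, or a longer alkyl chain in place of the aromatic ring.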